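Tolerance of a dichlorophenyl analogue in Vero cells

This account rests on a few compounds, and the source may have more. Where it says the series, first, only, none or still open, it means among the compounds named here.

Compound 1 `COC(=O)c1cc(-c2cccc(NC(=O)c3ccc(/C=C/C(=O)c4ccc(Br)cc4)cc3)c2)on1` and compound 2 `CCOC(=O)c1cc(-c2cccc(NC(=O)c3ccc(/C=C/C(=O)c4ccc(Cl)cc4)cc3)c2)on1` share a common core and were tested in an ADME assay on Vero cells (Chlorocebus sabaeus) for cytotoxicity, read by MTT assay, with a stated time of 72 h; a lower number here means that less compound is tolerated, a higher number that more compound is tolerated. In this assay compound 1 gives > 20 ug/mL, which is a limit of the assay rather than a number. Compound 2 in this assay likewise gives > 80 ug/mL, again a limit. Compound 1 therefore stands only at the lower of two limits, as shown by the limit of > 20 ug/mL in this assay, at which 1 of the 2 values shown sits, and (the limit of > 80 ug/mL in this assay, at which 1 of the 2 values shown sits), so no step between measured compounds can be counted.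

The unmeasured compound 3 `COC(=O)c1cc(-c2cccc(NC(=O)c3ccc(/C=C/C(=O)c4ccc(Cl)cc4Cl)cc3)c2)on1` differs from compound 1 in one place: 2,4-dichlorophenyl in place of 4-bromophenyl on a carbonyl carbon. Without a measured step to draw on, no change beyond the usual scatter is expected in this assay from this exchange. On that view the expected step that the limit leaves unreadable from compound 1 to compound 3 is small, and the result is quite likely to be a limit once more. Compound 3 is expected to give 40 ug/mL, within a range from 15 ug/mL to 100 ug/mL.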

Compound 3, half-maximal cytotoxic concentration: > 40 ug/mL
Compound 3 gave a limit, no number; the forecaster's own chance of this, stated with the estimate: 65%; the middle value sits exactly at the limit.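

In this assay, within the data shown here, compound 1 and compound 3 both give only limits of the assay, so no step between them can be read. The compounds shown leave open where either value truly lies, and whether 2,4-dichlorophenyl in place of 4-bromophenyl changes tolerance at all.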